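Replacing methyl with cyclopropyl in compound 1

The source may hold more compounds than are shown below. What is called first, only, known or untested is meant among the compounds shown, and "the series" means these compounds.

Measured in a physicochemical assay for solubility, measured as kinetic solubility (a higher number here means a more soluble compound, a lower number a less soluble compound), so far:
- compound 1 `Cc1cc(-c2noc([C@H](C)NC(=O)c3cc(C(F)(F)F)nn3C)n2)ccn1` gives 179000 nM
- compound 2 `COc1cc(-c2noc([C@H](C)NC(=O)c3cc(C(F)(F)F)nn3C)n2)ccn1` gives 156000 nM
- compound 3 `C[C@H](NC(=O)c1cc(C(F)(F)F)nn1C)c1nc(-c2ccnc(N(C)C)c2)no1` gives 28000 nM

Compound 1 and compound 2 stand together at the top of these three numbers, within the scatter of each other, while compound 3 lies clearly lower. The next compound to be measured is compound 4 `C[C@H](NC(=O)c1cc(C(F)(F)F)nn1C)c1nc(-c2ccnc(C3CC3)c2)no1`, which carries cyclopropyl in place of methyl on an aromatic carbon.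

Going by the values given here, no measured step makes this exact change, but three steps at the same place bear on it. Methoxy in place of methyl gave almost nothing (a 1.1-fold lower number from compound 1 to compound 2 (0.06 log units; within the scatter)). Dimethylamino in place of methyl gave a modest drop (a 6.4-fold lower number from compound 1 to compound 3 (0.81 log units; beyond the scatter)), and dimethylamino in place of methoxy gave one of similar size (a 5.6-fold lower number from compound 2 to compound 3 (0.75 log units; beyond the scatter)). So the replacements at this place range from no change to a modest fall, and none has raised the number beyond the scatter. Compound 3 (a 6.4-fold lower number from compound 1 to compound 3 (0.81 log units; beyond the scatter)) sets the likely lower side of the expectation, and compound 2 (a 1.1-fold lower number from compound 1 to compound 2 (0.06 log units; within the scatter)) the upper side.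

A modest fall in this assay is therefore expected, estimated as a 3.0-fold lower number from compound 1 to compound 4 (0.47 log units; beyond the scatter) in all. Compound 4 is estimated at 60000 nM (expected range from 20000 nM to 170000 nM).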

Compound 4, solubility: 16000 nM
For compound 4 the middle estimate is 3.8-fold (0.57 log units) above the measured one, and the stated range ends above it.
By their numbers in this assay, from the lowest: compounds 4 and 3 (each within the scatter of the next); then compounds 2 and 1 (each within the scatter of the next).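

In this assay, going by these compounds alone, cyclopropyl in place of methyl on this aromatic carbon gives an 11-fold lower number from compound 1 to compound 4 (1.05 log units; beyond the scatter) and is the first change at this place to be printed as large. Adding only carbon here, with no hydrogen-bond donor or acceptor entering, is therefore enough to give a fall of this size, and the methyl and methoxy compounds stand apart from cyclopropyl, as the step of a 9.8-fold lower number from compound 2 to compound 4 (0.99 log units; beyond the scatter) also shows. Cyclopropyl and dimethylamino cannot be told apart in this assay, since the comparison gives a 1.8-fold lower number from compound 3 to compound 4 (0.24 log units; within the scatter) and stays within the scatter, so two groups with different entering atoms now share the lower level.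

The methyl to cyclopropyl change adds carbon atoms and a three-membered ring together, so these compounds leave open whether an open chain such as ethyl or isopropyl would fall as far, and whether a group such as a carboxylic acid or a primary amine could raise the number above that of compound 1. The data shown hold no separate measurement that accounts for the fall seen with cyclopropyl.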